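This account rests on a few compounds, and the source may have more. Where it says the series, first, only, none or still open, it means among the compounds named here.

Compound 1, `COc1ccc(Cn2cc(C(N)=O)c3c(N)ncnc32)cc1`, gives 47000 nM in a functional assay on KB cells (Homo sapiens) for cytotoxicity; a higher number here means a weaker inhibitor, a lower number a stronger inhibitor.
Compound 2, `Cc1ccc(Cn2cc(C#N)c3c(N)ncnc32)cc1`, reaches only the limit of > 100000 nM in this assay.
Compound 3, `NC(=O)c1cn(Cc2ccccc2)c2ncnc(N)c12`, gives 75000 nM in this assay.

Compound 3 holds the higher of the two plain numbers, but the step of a 1.6-fold higher number from compound 1 to compound 3 (0.20 log units; within the scatter) lies within the scatter, so compound 1 and compound 3 cannot be ranked against each other. The third value is not a number: the limit of > 100000 nM in this assay, at which 1 of the 3 values shown sits.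

Compound 4, `CCCn1cc(C(N)=O)c2c(N)ncnc21`, differs from compound 3 in one place: ethyl in place of phenyl on a saturated chain carbon bound to an aromatic nitrogen. Going by the values given here, the only measured step, a 1.6-fold higher number from compound 1 to compound 3 (0.20 log units; within the scatter), alters a substituent on the very phenyl that leaves here, so it speaks to a change on that ring rather than to its removal, and no measured step bears directly on swapping phenyl for ethyl. With nothing to set a direction, no step beyond the scatter is expected in this assay, and a reading at the limit remains possible.

Compound 4 is therefore estimated at about 100000 nM, expected to fall between 30000 nM and 300000 nM. The expected step of a 1.3-fold higher number from compound 3 to compound 4 (0.12 log units; within the scatter) is an estimate, not a measurement.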

Compound 4, half-maximal inhibitory concentration: 100000 nM
Beside the measured number, compound 4's estimate shows no gap at the digits printed, and the stated range covers the measured number.
By their numbers in this assay, from the lowest: compounds 1, 3 and 4 (each within the scatter of the next, the first and the last beyond it).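

Putting ethyl in place of phenyl on a saturated chain carbon bound to an aromatic nitrogen gives a 1.3-fold higher number from compound 3 to compound 4 (0.12 log units; within the scatter) in this assay. The earlier step only altered a substituent on the phenyl ring, whereas this one removes the whole ring and still leaves no difference that can be read, so the ring is not required for a reading of this size. Little room remains for any higher reading, because compound 2 sits at a limit of the assay: the limit of > 100000 nM in this assay, at which 1 of the 4 values shown sits.

Going by these compounds, it remains open how this position would respond to a longer chain, an amine or a carboxylic acid in place of the ethyl. On these data alone, it is also open whether any such group could bring a reading clearly lower than those of compound 3 and compound 4.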